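Phenyl in place of piperidin-1-yl on compound 2

The source may report more compounds than this note shows. Statements on the series, on what has been measured and on what is new or still open speak of the compounds shown alone.

Four compounds are in view: compound 1 (`Cc1cc(=O)c2c(O)cc(OC/C=C/c3ccccc3)c([C@H]3CCN(C)C[C@H]3O)c2o1`), compound 2 (`Cc1cc(=O)c2c(O)c(CN3CCC(N4CCCCC4)CC3)c(O)c([C@H]3CCN(C)C[C@H]3O)c2o1`), compound 3 (`Cc1cc(=O)c2c(O)c(CN3CCCC3)c(O)c([C@H]3CCN(C)C[C@H]3O)c2o1`) and the unmeasured compound 4 (`Cc1cc(=O)c2c(O)c(CN3CCC(c4ccccc4)CC3)c(O)c([C@H]3CCN(C)C[C@H]3O)c2o1`). In a functional assay on MIA PaCa-2 cells (Homo sapiens) for inhibition, read by MTT assay, with a stated time of 48 h, tested at 10 uM (a lower number here means less inhibition of growth, a higher number more inhibition of growth at the concentration tested), compound 1 gives 11% and compound 3 gives 28% while compound 2 gives 23% on the same scale. Compound 2 thus lies within the scatter of compound 3 and beyond the scatter above compound 1.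

The step to compound 4 puts phenyl in place of piperidin-1-yl on a saturated ring carbon. Going by the values given here, no measured pair isolates this change, so the evidence is indirect. Compound 2 at 23% and compound 3 at 28% carry different side chains and stay within the scatter of each other, which is the only basis for expecting no large move. An estimated a number 5 percentage points higher from compound 2 to compound 4 (within the scatter) is expected in this assay as a slight upward move that stays within the scatter. For compound 4 the estimated value is 28% with an expected range from 12% to 48% in repeated measurements.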

Compound 4, percent growth inhibition at one concentration: 16%
Compound 4: the middle estimate sits 12 percentage points above what was measured; the range from low to high includes it.
By their numbers in this assay, from the lowest: compounds 1, 4, 2 and 3 (each within the scatter of the next, the first and the last beyond it).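

In this assay, going by these compounds alone, the exchange of piperidin-1-yl for phenyl gives a number 7 percentage points lower from compound 2 to compound 4 (within the scatter) and is the first direct reading at this position, on a saturated ring carbon three ring bonds from the ring nitrogen. At this single concentration, the series therefore does not separate a six-membered non-aromatic ring with 1 hetero atom from a six-membered aromatic ring of carbon only, even though the hydrogen-bond acceptor of piperidin-1-yl is lost in the exchange. Nothing on hand explains the step or shows what either group does in the cells.

Still open, as far as these compounds go, is whether a carboxylic acid, a dimethylamino group or a longer alkyl chain on the same ring carbon would move the number beyond the scatter. Also open, from the compounds shown here alone, is whether the small difference between piperidin-1-yl and phenyl would persist at other concentrations.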